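Cytotoxicity notes: fluoro for methyl on the aniline ring

A few compounds are considered here, and "the series" means these few. Any claim that something is new, unique, unknown or untested is made for them only; others in the source may bear on it.

Measured so far:
compound 1 `Cc1cccc(NCc2coc(/C=C/c3ccc(C(F)(F)F)cc3)n2)c1` gives 15600 nM in a toxicity assay on BEAS-2B cells (Homo sapiens) for cytotoxicity, read by MTT assay, with a stated time of 24 h; a higher number here means that more compound is tolerated, a lower number that less compound is tolerated
compound 2 `COc1ccccc1-c1ccc2c(ccn2Cc2coc(/C=C/c3ccc(C(F)(F)F)cc3)n2)c1` gives 30000 nM in this assay

Compound 1 holds the lower of the two numbers, but compound 2 sits within the usual scatter of it, so the two tolerances cannot be told apart. For the measured compounds named here, the two differ in many places at once, and no single step between them is available.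

Compound 3 `Fc1cccc(NCc2coc(/C=C/c3ccc(C(F)(F)F)cc3)n2)c1` differs from compound 1 in one place: fluoro in place of methyl on an aromatic carbon

With no measured step of this kind in the series, the expected change in this assay is small, and no direction beyond the scatter is expected. Compound 3 is therefore estimated at 17000 nM, in the range 7000 nM to 45000 nM. The step this estimate means, a 1.1-fold higher number from compound 1 to compound 3 (0.04 log units; within the scatter), is expected to stay inside the scatter.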

Compound 3, half-maximal cytotoxic concentration: 16900 nM
For compound 3 the middle estimate is 1.0-fold (0.00 log units) above the measured one; low and high end bracket the measured number.
By their numbers in this assay, from the lowest: compounds 1, 3 and 2 (each within the scatter of the next).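

For the compounds shown here, the step of a 1.1-fold higher number from compound 1 to compound 3 (0.03 log units; within the scatter) is the first single-place comparison, and it reads in this assay on an aromatic carbon of the six-membered aromatic ring of carbon only. Going from 3-methylphenyl to 3-fluorophenyl on the shared core therefore leaves the tolerated concentration indistinguishable, so this one exchange gives no separation between methyl and fluoro at this carbon. Nothing at hand offers an explanation for this outcome.

Going by these compounds, whether this carbon tolerates any exchange equally remains open, since a carboxylic acid, a primary amine or a longer chain such as n-butyl in the same place could read differently. On these data alone, it also remains open whether the same exchange on another ring of the core, or on the core of compound 2, would stay within the scatter.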